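Isobutoxy in place of benzylcarbamoyl on the shared core

The source may report more compounds than this note shows. Statements on the series, on what has been measured and on what is new or still open speak of the compounds shown alone.

Three compounds share one core and differ only at a saturated ring carbon. In a functional assay on HEK293 cells for agonist activity at G-protein coupled receptor 39 (Homo sapiens), read by scintillation proximity assay and inositol phosphate accumulation, with a stated time of 75 min, in the presence of a further agent that is not named here (a lower number here means that less compound is needed, a higher number that more compound is needed for the effect), compound 1 `Cc1nn(-c2ncnc3nc[nH]c23)c2c1C(OC1CCCC1)CC(=O)N2` gives 2 nM, compound 2 `Cc1nn(-c2ncnc3nc[nH]c23)c2c1C(c1ccc(F)cc1Cl)CC(=O)N2` gives 9 nM, and compound 3 `Cc1nn(-c2ncnc3nc[nH]c23)c2c1C(C(=O)NCc1ccccc1)CC(=O)N2` gives 5 nM. The steps are modest: a 4.5-fold higher number from compound 1 to compound 2 (0.65 log units; beyond the scatter) and a 2.5-fold higher number from compound 1 to compound 3 (0.40 log units; beyond the scatter), while a 1.8-fold lower number from compound 2 to compound 3 (0.26 log units; within the scatter). Compound 3 thus stands second of the three numbers, within the scatter of compound 2 and beyond it relative to compound 1.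

Compound 4 `Cc1nn(-c2ncnc3nc[nH]c23)c2c1C(OCC(C)C)CC(=O)N2` is not yet measured. It differs from compound 3 as follows: isobutoxy in place of benzylcarbamoyl on a saturated ring carbon. The cyclopentyloxy of compound 1 is the nearest measured relative of the entering isobutoxy, and compound 1 gives the lowest number of the set, so the step bearing most on this change is a 2.5-fold higher number from compound 1 to compound 3 (0.40 log units; beyond the scatter), run in reverse. A small lower number is therefore expected in this assay, close to or within the scatter. The estimate for compound 4 is 3 nM, with a range of 1 nM to 9 nM, which is expected to mean a 1.7-fold lower number from compound 3 to compound 4 (0.22 log units; within the scatter).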

Compound 4, half-maximal effective concentration: 4 nM
Compound 4: the middle estimate sits 1.3-fold (0.12 log units) below what was measured; the range from low to high includes it.
By their numbers in this assay, from the lowest: compounds 1, 4, 3 and 2 (each within the scatter of the next, the first and the last beyond it).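

In this assay, the open-chain isobutoxy stands level with benzylcarbamoyl on this saturated ring carbon, with a 1.3-fold lower number from compound 3 to compound 4 (0.10 log units; within the scatter), so the aromatic ring and hydrogen-bond donor of the leaving group can be removed here without a change beyond the scatter. On the oxygen, isobutyl in place of cyclopentyl gives a 2.0-fold higher number from compound 1 to compound 4 (0.30 log units; within the scatter), so among these two ethers the ring is not needed to keep the number low. Only the comparison with the 2-chloro-4-fluorophenyl compound separates, with a 2.3-fold lower number from compound 2 to compound 4 (0.35 log units; beyond the scatter), a modest step in favour of the ether.

Nothing shown gives a reason for any of these steps. As far as these compounds go, it stays open whether a shorter ether such as methoxy, an amine or a carboxylic acid on this carbon would keep the number in this range.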